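The compounds below may be only part of what the source reports. "The series", "measured", "known", "first", "only" and "open" are said of these compounds alone.

Measured compounds:
Compound 1, `CN1CCN(c2cc(C(F)(F)F)nc(SCc3ccc(C(F)(F)F)cc3)n2)CC1`; in a functional assay on PC-3 cells (Homo sapiens) for inhibition, read by MTT assay, with a stated time of 72 h (on this read-out lower numbers stand for stronger inhibition and higher numbers for weaker inhibition), compound 1 gives 34700 nM.
Compound 2, `FC(F)(F)c1ccc(CSc2nc(N3CCN(c4ccccc4)CC3)cc(C(F)(F)F)n2)cc1`; in this assay compound 2 gives 42700 nM.

For the measured compounds named here, compound 2 stands at one end of these two numbers, but the only step that reaches it, a 1.2-fold higher number from compound 1 to compound 2 (0.09 log units; within the scatter), is within the scatter, so the two compounds are not told apart by this read-out. Compound 3, `FC(F)(F)c1ccc(CSc2nc(N3CCN(c4ncccn4)CC3)cc(C(F)(F)F)n2)cc1`, differs from compound 2 in one place: pyrimidin-2-yl in place of phenyl on an amine nitrogen in a ring. Going by the values given here, the single measured step at this place, phenyl in place of methyl on the amine nitrogen in the ring, hardly moved the number, and no measured pair exchanges phenyl for pyrimidin-2-yl anywhere. With only that to go on, the expectation is for no step beyond the scatter, a 1.1-fold lower number from compound 2 to compound 3 (0.03 log units; within the scatter). Compound 3 is therefore estimated at 40000 nM in this assay, within a range from 15000 nM to 110000 nM.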

Compound 3, half-maximal inhibitory concentration: > 50000 nM
Compound 3: only a limit was reported; the forecaster's own chance of this, stated with the estimate: 15%; at least 1.2-fold (0.09 log units) between middle value and limit.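

In this assay compound 3 gives no number, only a limit: the limit of > 50000 nM in this assay, at which 1 of the 3 values shown sits. Swapping the groups on the amine nitrogen in the ring gives an at least 1.1-fold higher number from compound 2 to compound 3 (0.06 log units; that floor lies within the scatter), and an at least 1.4-fold higher number from compound 1 to compound 3 (0.15 log units; that floor lies within the scatter), so each step is known only as a floor, and each floor is small. What is new is that a third group at this position, a ring holding two nitrogen atoms in place of a ring of carbon only, does not give a lower number, and so none of methyl, phenyl and pyrimidin-2-yl is shown to give stronger inhibition than another.

As far as these compounds go, how far compound 3 really lies from compound 2 stays open. So does whether a quite different group on this nitrogen, such as a benzyl group, an acetyl group or a chain ending in a carboxylic acid, would give a clearly lower number.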